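The source may hold more compounds than are shown below. What is called first, only, known or untested is meant among the compounds shown, and "the series" means these compounds.

Measured compounds:
- compound 1, `COc1cc2ncnc(Nc3ccc(C)cc3)c2cc1OCCCSc1nc2ccccc2s1`: 14300 nM
- compound 2, `COc1cc2ncnc(Nc3ccc(F)c(Cl)c3)c2cc1OCCCSc1nc2ccccc2o1`: 4050 nM
- compound 3, `CCc1cc(Br)ccc1Nc1ncnc2cc(OC)c(OCCCSc3nc4ccccc4o3)cc12`: 17300 nM

All three compounds share one core and were tested in a functional assay on MCF7 cells (Homo sapiens) for cytotoxicity, read by MTT assay, with a stated time of 24 h; a higher number here means a weaker inhibitor, a lower number a stronger inhibitor. Compound 3 carries the highest number of the three; its nearest neighbour is compound 1, whose number is within the scatter of it, while compound 2 sits clearly lower, as the step of a 4.3-fold higher number from compound 2 to compound 3 (0.63 log units; beyond the scatter) shows.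

The next compound, compound 4 with the structure `COc1cc2ncnc(Nc3ccc(C)cc3)c2cc1OCCCSc1nc2ccccc2o1`, differs from compound 3 in one place: 4-methylphenyl in place of 4-bromo-2-ethylphenyl on a nitrogen on an aromatic ring. For the measured compounds named here, only one measured step changes the group on that nitrogen, the step of a 4.3-fold higher number from compound 2 to compound 3 (0.63 log units; beyond the scatter), and it swaps a different pair of groups, so it gives a size but not a direct guide. Compound 1 carries the same 4-methylphenyl group that enters here, and in this assay compound 1 gives 14300 nM, a number within the scatter of compound 3. On that basis the expected step of a 1.2-fold lower number from compound 3 to compound 4 (0.09 log units; within the scatter) is small, not beyond the scatter. The estimate for compound 4 in this assay is therefore 14000 nM, with a range from 6000 nM to 35000 nM.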

Compound 4, half-maximal inhibitory concentration: 12100 nM
Estimate against measurement, compound 4: 1.2-fold (0.06 log units) above; low and high end bracket the measured number.
By their numbers in this assay, from the lowest: compound 2; then compounds 4, 1 and 3 (each within the scatter of the next).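

In this assay, 4-methylphenyl in place of 4-bromo-2-ethylphenyl on the nitrogen gives a 1.4-fold lower number from compound 3 to compound 4 (0.16 log units; within the scatter), so these two groups cannot be told apart at this position, although only the group that leaves carries a bromine. For the compounds shown here, the 3-chloro-4-fluorophenyl group of compound 2 now stands apart from two different groups rather than one: besides a 4.3-fold higher number from compound 2 to compound 3 (0.63 log units; beyond the scatter), there is also a 3.0-fold higher number from compound 2 to compound 4 (0.48 log units; beyond the scatter), which makes it the only one of the three groups on this nitrogen with a clearly lower number. The first view of the other end of the molecule comes from 1,3-benzoxazol-2-yl in place of 1,3-benzothiazol-2-yl on the sulfur, which gives a 1.2-fold lower number from compound 1 to compound 4 (0.07 log units; within the scatter), so this exchange leaves no difference that can be read when 4-methylphenyl sits on the nitrogen.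

Nothing available explains any of these numbers. From the compounds shown here alone, it remains open whether a phenyl ring carrying an amine or a carboxylic acid on this nitrogen, or a longer chain linking the shared core to the sulfur, would give a number near that of compound 2 or near that of compound 4.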